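The compounds below may be only part of what the source reports. "The series", "measured", "known", "first", "only" and "open" are said of these compounds alone.

Of the compounds shown here, three define the series so far. Compound 1 `Cc1ccc2[nH]c(=O)c(/C=N/c3ccc(C(=O)O)cc3)cc2c1` gives 409000 nM in a functional assay, read by spectrophotometry, with a stated time of 5 min; on this read-out lower numbers stand for stronger inhibition and higher numbers for weaker inhibition. Compound 2 `O=c1[nH]c2ccccc2cc1/C=N/c1ccccc1O` gives 237000 nM in this assay, and compound 3 `O=c1[nH]c2ccccc2cc1/C=N/Cc1ccccc1` gives 329000 nM. The three numbers fall within the usual scatter of one another, so compound 2 is not set apart from either neighbour. Compound 4 `Cc1ccc2[nH]c(=O)c(/C=N/c3ccccc3O)cc2c1` is not yet measured. It differs from compound 2 by one change: methyl in place of hydrogen on an aromatic carbon. Within the data shown here, no measured pair isolates this change, so only the spread of the three numbers guides expectation. A step from compound 2 to compound 4 of no more than the scatter is expected, with no clear direction, as a 1.1-fold higher number from compound 2 to compound 4 (0.02 log units; within the scatter). Compound 4 is accordingly estimated at 250000 nM, within 120000 nM to 500000 nM.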

Compound 4, half-maximal inhibitory concentration: 286000 nM
Estimate against measurement, compound 4: 1.1-fold (0.06 log units) below; the range from low to high includes it.
By their numbers in this assay, from the lowest: compounds 2, 4, 3 and 1 (each within the scatter of the next).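

In this assay, methyl in place of hydrogen on this aromatic carbon, meta to a fused ring and para to a fused ring, gives a 1.2-fold higher number from compound 2 to compound 4 (0.08 log units; within the scatter). Among these compounds, this is the first step that isolates a single change, and it leaves compound 2 and compound 4 indistinguishable on this read-out. Nothing available explains this result. From the compounds shown here alone, it remains open whether an amine, a carboxylic acid or a longer chain on this carbon would give a step beyond the scatter. Going by these compounds, whether methyl here gives a similar step alongside other changes elsewhere also remains open.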